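Methyl for Isopropyl on a Chloro Core: Expected Step

A few compounds are considered here, and "the series" means these few. Any claim that something is new, unique, unknown or untested is made for them only; others in the source may bear on it.

Compound 1 `CC(C)n1c(/C=C2/C(=O)Nc3ccc(F)cc32)nc2ccccc21` is measured in a functional assay on HGC cells (Homo sapiens) for cytotoxicity, read by MTT assay, with a stated time of 48 h (on this read-out higher numbers stand for weaker inhibition and lower numbers for stronger inhibition), where compound 1 gives 28000 nM. Compound 2 `Cn1c(/C=C2/C(=O)Nc3ccc(F)cc32)nc2ccccc21` differs from compound 1 by methyl in place of isopropyl on an aromatic nitrogen; in this assay compound 2 gives 37800 nM, a step of a 1.4-fold higher number from compound 1 to compound 2 (0.13 log units; within the scatter). Compound 3 `CC(C)n1c(/C=C2/C(=O)Nc3ccc(Cl)cc32)nc2ccccc21` carries a different core, differing from compound 1 by chloro in place of fluoro on an aromatic carbon; in this assay compound 3 gives 32800 nM, a step of a 1.2-fold higher number from compound 1 to compound 3 (0.07 log units; within the scatter). Compound 4 `Cn1c(/C=C2/C(=O)Nc3ccc(Cl)cc32)nc2ccccc21` is not yet measured and differs from compound 3 by methyl in place of isopropyl on an aromatic nitrogen, the same change that was made from compound 1 to compound 2. For compound 4 the step is expected to be a 1.3-fold higher number from compound 3 to compound 4 (0.13 log units; within the scatter), resting on the earlier one, because a 1.4-fold higher number from compound 1 to compound 2 (0.13 log units; within the scatter) stayed within the scatter. Compound 4 is therefore expected to give about 44000 nM in this assay, with a likely range from 25000 nM to 80000 nM.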

Compound 4, half-maximal inhibitory concentration: 43600 nM
For compound 4 the middle estimate is 1.0-fold (0.00 log units) above the measured one; low and high end bracket the measured number.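

In this assay, methyl in place of isopropyl gives a 1.3-fold higher number from compound 3 to compound 4 (0.12 log units; within the scatter), which matches the same change made on the other core: the same change on two cores in this assay, a 1.4-fold higher number (0.13 log units; within the scatter) from compound 1 to compound 2 and a 1.3-fold higher number (0.12 log units; within the scatter) from compound 3 to compound 4, 1.0-fold (0.01 log units) apart, within the scatter of two such steps

Chloro in place of fluoro gives a 1.2-fold higher number from compound 2 to compound 4 (0.06 log units; within the scatter), and this step also matches its earlier counterpart: the same change on two cores in this assay, a 1.2-fold higher number (0.07 log units; within the scatter) from compound 1 to compound 3 and a 1.2-fold higher number (0.06 log units; within the scatter) from compound 2 to compound 4, 1.0-fold (0.01 log units) apart, within the scatter of two such steps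

Within the data shown here, each change therefore looks alike on both cores, but every step lies within the scatter, so this shows only that neither change has a measurable effect here, not that a real effect carries from one core to another.

Still open, as far as these compounds go, is whether a longer chain or a chain ending in an amine on the aromatic nitrogen would give a step beyond the scatter. The same question applies to a nitrile or a methoxy group in place of the halogen.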